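The source may report more compounds than this note shows. Statements on the series, on what has been measured and on what is new or still open speak of the compounds shown alone.

Of the compounds shown here, three sharing one core have been tested in a functional assay on T47D cells (Homo sapiens) for antiproliferative activity, read by MTT assay, with a stated time of 72 h; a higher number here means a weaker inhibitor, a lower number a stronger inhibitor. Compound 1 `O=C(Nc1ccc(Cl)c(-c2nnc3c(Cl)cccn23)c1)c1ccc(F)cc1Cl` carries a 2-chloro-4-fluorophenyl on its carbonyl carbon, and in this assay compound 1 gives > 100000 nM, which is a limit of the assay rather than a number. Compound 2 `O=C(Nc1ccc(Cl)c(-c2nnc3c(Cl)cccn23)c1)c1ccc(Cl)cc1` carries a 4-chlorophenyl there, and in this assay compound 2 likewise gives only a limit, > 100000 nM. Among the compounds with values here, compound 3 `O=C(Nc1ccc(Cl)c(-c2nnc3c(Cl)cccn23)c1)c1cccc(Cl)c1`, with a 3-chlorophenyl, is the only one with a measured number: in this assay compound 3 gives 30200 nM. Compound 2 therefore stands at the limit of > 100000 nM in this assay, at which 2 of the 3 values shown sit.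

Compound 4 `CS(=O)(=O)c1cccc(C(=O)Nc2ccc(Cl)c(-c3nnc4c(Cl)cccn34)c2)c1` has not yet been measured. It differs from compound 2 in one place: 3-(methylsulfonyl)phenyl in place of 4-chlorophenyl on a carbonyl carbon. Within the data shown here, two measured steps bear on this change, both ending at compound 3 with its 3-chlorophenyl: an at least 3.3-fold lower number from compound 1 to compound 3 (0.51 log units; beyond the scatter) and an at least 3.3-fold lower number from compound 2 to compound 3 (0.51 log units; beyond the scatter). A 3-substituted phenyl has so far brought the number down out of the limit, so a step in the lowering direction is expected for compound 4 as well, an at least 2.5-fold lower number from compound 2 to compound 4 (0.39 log units; beyond the scatter), with the methylsulfonyl adding uncertainty. Compound 4 is estimated at 40000 nM, between 10000 nM and 150000 nM.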

Compound 4, half-maximal inhibitory concentration: > 100000 nM
Compound 4 was reported as a limit; the forecaster's own chance of this, stated with the estimate: 40%; middle value at least 2.5-fold (0.39 log units) from the limit.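

Methylsulfonyl in place of chloro on an aromatic carbon gives an at least 3.3-fold higher number from compound 3 to compound 4 (0.51 log units; beyond the scatter), so having a substituent on a 3-substituted phenyl is not enough in itself: of the two such compounds, only the one with 3-chlorophenyl gives a measured number. The steps to compound 4 from compound 1 and from compound 2 cannot be read, as both ends of each are limits of the assay. Compound 2 therefore keeps its place in the series: the limit of > 100000 nM in this assay, at which 3 of the 4 values shown sit.

On these data alone, what remains open is whether an amine or a carboxylic acid in place of the chloro of compound 3 would give a measured number or another limit. Also open, as far as these compounds go, is how far compound 1, compound 2 and compound 4 really differ, as their limits hide any such differences.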